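Adding Iodine to a Weakly Active Core

A few compounds are considered here, and "the series" means these few. Any claim that something is new, unique, unknown or untested is made for them only; others in the source may bear on it.

Measured compounds:
compound 1, `COc1ccc(-c2cc(=O)c3c(OC)cc(OC)cc3[nH]2)cc1`: > 31100 nM
compound 2, `COc1ccc(-c2cc(=O)c3c(OC)cc(OC)cc3n2C)cc1`: "not determined" (no result reported)

In a functional assay on HepG2 cells (Homo sapiens) for antiproliferative activity, with a stated time of 72 h (a higher number here means that more compound is needed for the effect, a lower number that less compound is needed), compound 1 gives > 31100 nM. This is a limit of the assay and not a number, so compound 1 stands only at the edge of what the assay can report, at the limit of > 31100 nM in this assay, at which 1 of the 2 values shown sits. For compound 2 the result in this assay is "not determined" (no result reported), so it adds nothing that can be compared. Among the measured compounds shown here, no step between two measured compounds exists here, and so there is no measured comparison to build on.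

Compound 3, `COc1ccc(-c2[nH]c3cc(OC)cc(OC)c3c(=O)c2I)cc1`, differs from compound 1 in one place: iodo in place of hydrogen on an aromatic carbon. Because compound 1 gives only a limit, a step toward more compound needed cannot be seen, while a step toward less compound needed could be; I expect a moderate step of the latter kind in this assay, but its size is uncertain. Compound 3 is expected to give 12000 nM, within 2000 nM to 60000 nM. The expected step is an at least 2.5-fold lower number from compound 1 to compound 3 (0.41 log units; beyond the scatter), with a real chance that only a limit is reported again.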

Compound 3, half-maximal effective concentration: > 86200 nM
Compound 3 was reported as a limit; the forecaster's own chance of this, stated with the estimate: 40%; middle value at least 7.1-fold (0.85 log units) away from the limit.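

In this assay compound 3 gives > 86200 nM, which is a limit and not a number. Compound 1 gives > 31100 nM, also a limit. Among the compounds shown here, no step from compound 1 to compound 3 can be read from these two limits. The compounds shown leave open whether iodo in place of hydrogen on an aromatic carbon changes how much compound is needed.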